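A Chloro Group Added to the Ethoxy Compound

The source may report more compounds than this note shows. Statements on the series, on what has been measured and on what is new or still open speak of the compounds shown alone.

In a functional assay on the whole organism (strain Sprague-Dawley) for inhibition, with Rattus norvegicus as the target, with a stated time of 10 min (a higher number here means that more compound is needed for the effect, a lower number that less compound is needed), compound 1 (`O=C(O)c1cnc(-c2ccccc2F)[nH]c1=O`) gives 5 mg/kg, and compound 2 (`CCOc1ccccc1-c1ncc(C(=O)O)c(=O)[nH]1`) gives 0.5 mg/kg, the lower of the two numbers. Compound 3 (`CCOc1ccc(Cl)cc1-c1ncc(C(=O)O)c(=O)[nH]1`) keeps the ethoxy group of compound 2 and has chloro in place of hydrogen on an aromatic carbon, para to the ethoxy group: chloro in place of hydrogen on an aromatic carbon. Going by the values given here, only one measured step bears on this change, and it bears only loosely: a 10-fold lower number from compound 1 to compound 2 (1.00 log units; beyond the scatter), with ethoxy in place of fluoro. Among the compounds with values here, that step was modest and involved a different group, and no measured step shows what chloro does here. As far as these compounds go, no change beyond the scatter in this assay is therefore expected, and the direction remains open. The expected change is a 1.3-fold lower number from compound 2 to compound 3 (0.10 log units; within the scatter). Compound 3 is estimated at 0.4 mg/kg, with an expected range of 0.12 mg/kg to 1.5 mg/kg.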

Compound 3, dose for 50% inhibition: 0.5 mg/kg
Compound 3: middle estimate off by 1.3-fold (0.10 log units), on the low side; the range from low to high includes it.
By their numbers in this assay, from the lowest: compounds 2 and 3 (each within the scatter of the next); then compound 1.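

In this assay, putting chloro on an aromatic carbon para to an ethoxy group gives no change at the digits printed from compound 2 to compound 3 (within the scatter) and so leaves the number where it stood. Going by these compounds alone, the earlier compounds showed only that the group at the other site, ethoxy in place of fluoro, could move this number; this pair shows that the position para to the ethoxy group accepts a chlorine atom with no change beyond the scatter. Nothing measured here accounts for this result.

A single substituent cannot show whether this position is indifferent to groups in general, so an amine, a methoxy group or a carboxylic acid there might behave differently. As far as these compounds go, it also remains open whether chloro would give the same outcome on another carbon of this ring.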